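Shortening the chain on an isoxazole-type urea

The source may report more compounds than this note shows. Statements on the series, on what has been measured and on what is new or still open speak of the compounds shown alone.

For the measured compounds named here, compound 2 `CCCCCCCCCCCCCCc1cc(NC(=O)Nc2c(C(C)C)cccc2C(C)C)on1` stands at the higher of the two numbers so far. In an assay on microsomes from intestine for inhibition of acyl-CoA:cholesterol acyltransferase (Oryctolagus cuniculus) (on this read-out higher numbers stand for weaker inhibition and lower numbers for stronger inhibition), compound 2 gives 28 nM. Compound 1 `CCCCCCCCCCCCCCN1NN=C(NC(=O)Nc2c(C(C)C)cccc2C(C)C)N1` is the nearest point of comparison, and in this assay compound 1 gives 12 nM, a gap beyond the scatter, so compound 2 is the weaker of the two.

Compound 3 `CCCCCCCCCCc1cc(NC(=O)Nc2c(C(C)C)cccc2C(C)C)on1` is the next compound to be measured. The change from compound 2 is hydrogen in place of butyl on a saturated chain carbon, ten or more bonds along the chain from an aromatic carbon; the chain is cut shorter while the rest of the molecule is kept. Going by the values given here, no pair of measured compounds shows what such a cut does here, so the direction of the step is not fixed by the data. A modest weakening is expected, with the step of a 2.1-fold higher number from compound 2 to compound 3 (0.33 log units; beyond the scatter) estimated as a small loss that may still sit within the scatter. Compound 3 is therefore expected to give about 60 nM in this assay, with a range from 20 nM to 200 nM.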

Compound 3, half-maximal inhibitory concentration: 29 nM
For compound 3 the middle estimate is 2.1-fold (0.32 log units) above the measured one, and the stated range covers the measured number.
By their numbers in this assay, from the lowest: compound 1; then compounds 2 and 3 (each within the scatter of the next).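

In this assay, replacing butyl with hydrogen on this saturated chain carbon gives a 1.0-fold higher number from compound 2 to compound 3 (0.02 log units; within the scatter), so the assay cannot tell the two compounds apart. For the compounds shown here, this is the first measured pair that differs in one place, and it shows that on this core the chain of compound 2 can lose its butyl portion without a difference beyond the scatter. Nothing measured here accounts for this result.

Going by these compounds, the pair covers only one cut, so it remains open whether a much shorter chain, such as butyl or ethyl in the same place, or a longer chain than that of compound 2 would read the same. On these data alone, it is also open whether the same cut would read alike on the core of compound 1, or what an amine or a carboxylic acid on the chain would do.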